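The source may report more compounds than this note shows. Statements on the series, on what has been measured and on what is new or still open speak of the compounds shown alone.

Measured compounds:
- compound 1, `N#C/C(=C\N1CCN(C(=O)c2ccco2)C1=S)C(=O)Nc1ccc(Cl)cc1`, 14200 nM in a functional assay on M14 cells (Homo sapiens) for inhibition, read by sulforhodamine B assay, with a stated time of 48 h; on this read-out lower numbers stand for stronger inhibition of growth and higher numbers for weaker inhibition of growth
- compound 2, `N#C/C(=C\N1CCN(C(=O)c2ccco2)C1=S)C(N)=O`, 16500 nM in this assay

Among the measured compounds shown here, compound 2 and compound 1 are the only two compounds with numbers in this assay, and the two numbers lie within the scatter of each other: the step of a 1.2-fold higher number from compound 1 to compound 2 (0.07 log units; within the scatter) is the single measured step, and it is a small one. Compound 2 therefore stands nowhere in particular yet; no ordering between it and compound 1 can be read from these two values.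

Compound 3, `N#C/C(=C\N1CCN(C(=O)c2ccco2)C1=S)C(=O)c1ccccc1`, is the next compound and has not been measured in this assay. It differs from compound 2 by phenyl in place of amino on a carbonyl carbon. For the measured compounds named here, the only measured step that touches the same part of the shared core is the one from compound 1 to compound 2, which exchanged the group on the amide-type nitrogen and stayed within the scatter. On that basis a small step is expected for compound 3 as well, with no clear direction. The estimated step is a 1.3-fold lower number from compound 2 to compound 3 (0.10 log units; within the scatter). Compound 3 is thus expected to give about 13000 nM in this assay, within a range of 4000 nM to 40000 nM.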

Compound 3, concentration for 50% growth inhibition: 14900 nM
Compound 3: middle estimate off by 1.1-fold (0.06 log units), on the low side, and the stated range covers the measured number.
By their numbers in this assay, from the lowest: compounds 1, 3 and 2 (each within the scatter of the next).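

In this assay, the carbonyl carbon that also bears the double-bonded chain carbon now carries a group attached through carbon rather than nitrogen, and the read-out does not separate the two: phenyl in place of amino gives a 1.1-fold lower number from compound 2 to compound 3 (0.04 log units; within the scatter), and phenyl in place of (4-chlorophenyl)amino gives a 1.0-fold higher number from compound 1 to compound 3 (0.02 log units; within the scatter). The earlier pair varied only what sat on the amide-type nitrogen, whereas compound 3 lacks that nitrogen and its hydrogen-bond donor, and its number still lies within the scatter of both others. Carbamoyl and benzoyl therefore read alike at this position, as does the 4-chlorophenyl amide of compound 1, and no measurement at hand accounts for how close the three numbers lie.

The compounds shown leave open whether any group at this carbonyl carbon would move the number beyond the scatter, for instance a carboxylic acid, a methyl ester or a small alkyl ketone. They also leave open what the rest of the shared core contributes, since all three compounds keep it unchanged and every step shown falls at this one position.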